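Swapping the benzyl group on the most potent compound

The compounds below may be only part of what the source reports. "The series", "measured", "known", "first", "only" and "open" are said of these compounds alone.

Measured so far in a functional assay on MDA-MB-231 cells (Homo sapiens) for cytotoxicity, read by MTT assay, with a stated time of 24 h; on this read-out lower numbers stand for stronger inhibition and higher numbers for weaker inhibition
- compound 1 `COc1ccc(/C=C2\CN(Cc3cn(Cc4cccc(Cl)c4)nn3)C/C(=C\c3ccc(OC)cc3)C2=O)cc1` gives 98000 nM
- compound 2 `O=C1/C(=C/c2ccccc2F)CN(Cc2cn(Cc3cccc(Cl)c3)nn2)C/C1=C\c1ccccc1F` gives 12000 nM
- compound 3 `COc1ccc(/C=C2\CN(Cc3cn(Cc4ccc(F)cc4)nn3)C/C(=C\c3ccc(OC)cc3)C2=O)cc1` gives 70700 nM

Compound 2 has the lowest number of the three, and its gaps to compound 1 and to compound 3 both lie beyond the scatter. That makes it the most potent of this small set.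

The next compound to consider is compound 4 `O=C1/C(=C/c2ccccc2F)CN(Cc2cn(Cc3ccc(F)cc3)nn2)C/C1=C\c1ccccc1F`, which has not yet been measured. It differs from compound 2 in one place: 4-fluorophenyl in place of 3-chlorophenyl on a saturated chain carbon bound to an aromatic nitrogen. In words, 4-fluorophenyl stands in place of 3-chlorophenyl on a saturated chain carbon bound to an aromatic nitrogen, so 3-chlorobenzyl becomes 4-fluorobenzyl.

Going by the values given here, only one measured step makes this same exchange, and it lies within the scatter. It is a single pair, so the evidence is thin, and nothing measured shows whether compound 2 will respond in the same way. Going by a 1.4-fold lower number from compound 1 to compound 3 (0.14 log units; within the scatter), no step beyond the scatter is expected for compound 4 in this assay, and no firm direction either.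

The expected change is a 1.2-fold lower number from compound 2 to compound 4 (0.08 log units; within the scatter), which is only an estimate. For compound 4 the estimated value is 10000 nM, with an expected range from 4500 nM to 22000 nM.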

Compound 4, half-maximal inhibitory concentration: 10000 nM
Beside the measured number, compound 4's estimate shows no gap at the digits printed; low and high end bracket the measured number.
By their numbers in this assay, from the lowest: compounds 4 and 2 (each within the scatter of the next); then compounds 3 and 1 (each within the scatter of the next).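

On the core of compound 2, replacing 3-chlorobenzyl with 4-fluorobenzyl gives a 1.2-fold lower number from compound 2 to compound 4 (0.08 log units; within the scatter) in this assay, so the change again stays within the scatter. Until now this exchange had been read on one core only, which left open whether its small size was particular to that core; it has now been read on two, and the two steps agree: the same change on two cores in this assay, a 1.4-fold lower number (0.14 log units; within the scatter) from compound 1 to compound 3 and a 1.2-fold lower number (0.08 log units; within the scatter) from compound 2 to compound 4, 1.2-fold (0.06 log units) apart, within the scatter of two such steps

Going by these compounds alone, for these two cores, then, 3-chlorophenyl and 4-fluorophenyl on a saturated chain carbon bound to an aromatic nitrogen cannot be told apart in this read-out, although that finding covers only this one pair of groups and gives no reason for the match.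

The compounds shown carry only these two groups at this position, so it remains open whether a group of another kind there, such as an amine, a carboxylic acid or a longer chain, would shift the number beyond the scatter. Going by these compounds, all the numbers also come from a single cell line at a single stated time, so whether the two groups would still match in other cells is unknown.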